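Replacing the Hydroxycyclohexyl Group with a Carbamoylcyclobutyl

This account rests on a few compounds, and the source may have more. Where it says the series, first, only, none or still open, it means among the compounds named here.

Measured so far in an assay on isolated protein for inhibition of protein kinase C delta type (Homo sapiens), read by TR-FRET, with a stated time of 2 h; on this read-out higher numbers stand for weaker inhibition and lower numbers for stronger inhibition:
Compound 1, `N#Cc1cnc(NCc2cnccc2C(F)(F)F)cc1N[C@H]1CC[C@@H](O)CC1`, gives 4500 nM.
Compound 2, `N#Cc1cnc(NCc2ccccc2C(F)(F)F)cc1N[C@H]1CC[C@@H](O)CC1`, gives 4500 nM.
Compound 3, `N#Cc1cnc(NCc2ccccc2C(F)(F)F)cc1N[C@H]1CC[C@H](O)CC1`, gives > 10000 nM, which is a limit of the assay and not a number.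

Compound 3 therefore stands at the edge of what this assay can report, a position shared by one of the three values shown (the limit of > 10000 nM in this assay, at which 1 of the 3 values shown sits). Among the compounds with values here, the only single-point step measured is an at least 2.2-fold higher number from compound 2 to compound 3 (0.34 log units; beyond the scatter), a change that rests solely on configuration because of the fact that compounds 2 and 3 differ only in the configuration as drawn.

Compound 4, `N#Cc1cnc(NCc2ccccc2C(F)(F)F)cc1N[C@H]1C[C@@H](C(N)=O)C1`, is built from compound 3 by a different kind of change: 3-carbamoylcyclobutyl in place of 4-hydroxycyclohexyl on a nitrogen on an aromatic ring. Within the data shown here, no measured step covers a swap of this group, so the step from compound 2 to compound 3 gives no direct guide, and the starting value for compound 3 is itself only a limit. With nothing to pull the number up or down, compound 4 is expected to remain weak, with an estimate of 12000 nM (range 2500 nM to 50000 nM). The step that this estimate implies is a step that the limit leaves unreadable from compound 3 to compound 4, and it should be read as no change beyond the scatter.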

Compound 4, half-maximal inhibitory concentration: 4200 nM
Compound 4: middle estimate off by 2.9-fold (0.46 log units), on the high side; the range from low to high includes it.
By their numbers in this assay, from the lowest: compounds 4, 1 and 2 (each within the scatter of the next). At a limit, above all of these: compound 3.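

In this assay compound 3 gives > 10000 nM, which is a limit of the assay and not a number. Putting 3-carbamoylcyclobutyl in place of 4-hydroxycyclohexyl on this nitrogen brings an at least 2.3-fold lower number from compound 3 to compound 4 (0.37 log units; beyond the scatter), whereas the same swap made on the other configuration of the hydroxycyclohexyl group brings a 1.1-fold lower number from compound 2 to compound 4 (0.03 log units; within the scatter). The 4-hydroxycyclohexyl group is therefore not required for inhibition at this level, since a four-membered ring carrying a carbamoyl group matches the better of the two hydroxycyclohexyl configurations within the scatter.

The compounds shown leave open whether the configuration of the cyclobutyl ring matters as much as that of the cyclohexyl ring did. They also leave open whether a carboxylic acid or an amine in place of the carbamoyl group would shift the number in either direction.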